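The compounds below may be only part of what the source reports. "The series", "measured", "known", "first", "only" and "open" are said of these compounds alone.

Measured in an ADME assay on MT4 cells (Homo sapiens) for cytotoxicity, read by MTT assay, with a stated time of 4 days; a higher number here means that more compound is tolerated, a lower number that less compound is tolerated:

- Compound 1 `CC(C)N(C)c1nc(Cc2c(F)cccc2F)cc(=O)[nH]1`: 85000 nM
- Compound 2 `CCN(CC)c1nc(Cc2c(F)cccc2F)cc(=O)[nH]1`: > 85000 nM (a limit of the assay, not a number)
- Compound 3 `Cc1c(Cc2c(F)cccc2F)nc(N(C)C(C)C)[nH]c1=O`: 79000 nM

Compound 3, at 79000 nM, stands level with compound 1, at 85000 nM. The methyl group that separates them gives a 1.1-fold lower number from compound 1 to compound 3 (0.03 log units; within the scatter), so it makes no visible difference in this assay.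

Compound 4 `Cc1c(Cc2c(F)cccc2F)nc(N2CCCC2)[nH]c1=O` keeps that methyl group and changes one other place. It carries pyrrolidin-1-yl in place of isopropyl(methyl)amino on an aromatic carbon, between two ring nitrogen atoms (pyrrolidin-1-yl in place of isopropyl(methyl)amino on an aromatic carbon). The swap keeps the size of the group but closes it into a ring.

The closest measured change at this place is a number no lower from compound 1 to compound 2 (the limit leaves the size open). Its size cannot be read, since compound 2 sits at a limit (the limit of > 85000 nM in this assay, at which 1 of the 3 values shown sits). Within the data shown here, it shows no fall in the number, but no measured compound has a ring at this place, so the evidence is thin. Compound 4 could also end up reported only as a limit.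

No step beyond the scatter is therefore expected in this assay, and the estimated change is a 1.1-fold lower number from compound 3 to compound 4 (0.05 log units; within the scatter). The expected value for compound 4 is 70000 nM, within an estimated range of 30000 nM to 110000 nM.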

Compound 4, half-maximal cytotoxic concentration: > 82000 nM
Compound 4 ended at the assay's limit (the forecaster's own chance of this, stated with the estimate: 35%); at least 1.1-fold (0.06 log units) between middle value and limit.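

The swap of isopropyl(methyl)amino for pyrrolidin-1-yl keeps the count of heavy atoms and closes the group into a five-membered ring, and in this assay it gives an at least 1.0-fold higher number from compound 3 to compound 4 (0.01 log units; that floor lies within the scatter). Among these compounds, this is the first ring seen at this place, between two ring nitrogen atoms, and it brings no measurable fall in the number on a compound that also carries the methyl group. Compound 4 has only a limit of the assay rather than a number, so how far the step really goes cannot be read: the limit of > 82000 nM in this assay, at which 1 of the 4 values shown sits.

Going by these compounds, what a different ring would do at this place stays open, whether the smaller azetidin-1-yl, the larger piperidin-1-yl or morpholin-4-yl with its second hetero atom, and the same holds for a plain amino group. It is also open whether the tolerance seen here would hold with a longer chain such as ethyl in place of the methyl group, since every compound shown keeps the rest of the shared core unchanged.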